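This account rests on a few compounds, and the source may have more. Where it says the series, first, only, none or still open, it means among the compounds named here.

In an in vitro ADME assay on microsomes from liver (Mus musculus) for pharmacokinetics, read by LC-MS, with a stated time of 10 min, tested at 1 uM (on this read-out higher numbers stand for fast clearance and lower numbers for slow clearance), two compounds with a shared core have been measured so far. Compound 1 `CN1C[C@H](C(=O)Nc2ccc(C(F)(F)F)cc2)[C@@H](c2ccc(/C=C/C(=O)Nc3ccccc3N)cc2)C1`, with 4-(trifluoromethyl)phenyl on an amide-type nitrogen, gives 23 mL/min/kg. Compound 2 `COc1cccc(NC(=O)[C@H]2CN(C)C[C@@H]2c2ccc(/C=C/C(=O)Nc3ccccc3N)cc2)c1`, with 3-methoxyphenyl in that place, gives 65 mL/min/kg, the higher of the two numbers, so it is the faster cleared of the pair. Within the data shown here, compound 3 `Cc1cc(NC(=O)[C@H]2CN(C)C[C@@H]2c2ccc(/C=C/C(=O)Nc3ccccc3N)cc2)ccc1F` keeps the rest of compound 2 and changes only this group: 4-fluoro-3-methylphenyl in place of 3-methoxyphenyl on an amide-type nitrogen. Among the measured compounds shown here, only one measured step bears on this change, made in the same place: a 2.8-fold higher number from compound 1 to compound 2 (0.45 log units; beyond the scatter). That step is modest and beyond the scatter, but a single pair cannot show how a new group will behave. The entering group shares fluorine with the group of compound 1 at 23 mL/min/kg, which is only a weak hint towards a lower number. The expected change is therefore small and downward, an estimated 1.6-fold lower number from compound 2 to compound 3 (0.21 log units; within the scatter), and it may not clear the scatter. For compound 3 the estimated clearance is 40 mL/min/kg, with an expected range from 20 mL/min/kg to 80 mL/min/kg.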

Compound 3, clearance: 62 mL/min/kg
Estimate against measurement, compound 3: 1.6-fold (0.19 log units) below; the range from low to high includes it.
By their numbers in this assay, from the lowest: compound 1; then compounds 3 and 2 (each within the scatter of the next).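

In this assay, putting 4-fluoro-3-methylphenyl in place of 3-methoxyphenyl on the amide-type nitrogen gives a 1.0-fold lower number from compound 2 to compound 3 (0.02 log units; within the scatter), so the read-out does not separate these two groups, although the oxygen of one gives way to a fluorine and a methyl in the other. Set against 4-(trifluoromethyl)phenyl, the new group gives a 2.7-fold higher number from compound 1 to compound 3 (0.43 log units; beyond the scatter), a step much like a 2.8-fold higher number from compound 1 to compound 2 (0.45 log units; beyond the scatter), so among these three compounds a fluorine on the ring does not by itself go with the lower number of compound 1. Nothing measured here explains why these groups give the numbers they do.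

As far as these compounds go, what remains open is which part of 4-(trifluoromethyl)phenyl goes with that lower number: its trifluoromethyl group, or simply having one group at the 4-position of the ring and none at the 3-position. A plain phenyl, a 4-chlorophenyl or a pyridine ring on the same nitrogen would help to tell these apart, and compound 1 alone cannot settle it.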